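A Bromine Moved Around the Ring on an Inactive Scaffold

The source may hold more compounds than are shown below. What is called first, only, known or untested is meant among the compounds shown, and "the series" means these compounds.

Compound 1 `Cc1cccc(-n2nncc2CN2C(=O)C3(C(C#N)=C(N)Oc4c3c3nc5ccccc5nc3c3ccccc43)c3ccccc32)c1` — in an ADME assay on HUVEC cells (Homo sapiens) for antiproliferative activity, read by MTT assay, with a stated time of 48 h (a lower number here means a stronger inhibitor, a higher number a weaker inhibitor), compound 1 stops at the assay limit, > 50000 nM.
Compound 2 `N#CC1=C(N)Oc2c(c3nc4ccccc4nc3c3ccccc23)C12C(=O)N(Cc1cnnn1-c1ccc(Br)cc1)c1ccccc12` — in this assay compound 2 likewise stops at the assay limit, > 50000 nM.

Compound 2 thus stands at the edge of what this assay can report, with no number of its own. Within the data shown here, the only measured step, a step that the two limits leave unreadable from compound 1 to compound 2, cannot be read, because both ends sit at the limit of > 50000 nM in this assay, at which 2 of the 2 values shown sit.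

Compound 3 `N#CC1=C(N)Oc2c(c3nc4ccccc4nc3c3ccccc23)C12C(=O)N(Cc1cnnn1-c1cccc(Br)c1)c1ccccc12` is the next member. It differs from compound 2 only in 3-bromophenyl in place of 4-bromophenyl on an aromatic nitrogen. Among the measured compounds shown here, no measured step bears on shifting a bromine around this phenyl ring, and the one step that exists is unreadable, so nothing supports an expectation of a real change.

The step is estimated as a step that the limit leaves unreadable from compound 2 to compound 3, that is, none beyond the scatter. Compound 3 is therefore expected to give about 60000 nM, within 15000 nM to 300000 nM, most likely again only as a limit.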

Compound 3, half-maximal inhibitory concentration: > 50000 nM
Compound 3 gave a limit, no number (the forecaster's own chance of this, stated with the estimate: 80%); the middle value is on the limit's open side.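

Compound 3 also stops at a limit of the assay, so neither its step from compound 2 nor its step from compound 1 can be read: the limit of > 50000 nM in this assay, at which 3 of the 3 values shown sit.

On these data alone, whether compound 1, compound 2 and compound 3 truly differ in this assay stays open, as does whether any change on this phenyl ring would give a readable value.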